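The compounds below may be only part of what the source reports. "The series", "measured", "known", "first", "only" and "open" are said of these compounds alone.

Series notes. Compound 1 `COc1ccc(OC)c(-c2cc(-c3ccc(C(=O)N(C)Cc4ccccc4)s3)on2)c1` was run in a functional assay on PC-3 cells (Homo sapiens) for cytotoxicity, read by XTT assay, with a stated time of 72 h; a higher number here means a weaker inhibitor, a lower number a stronger inhibitor. Compound 1 gives > 30000 nM, which is a limit of the assay rather than a number. Among the measured compounds shown here, it is the single value that sits at the limit of > 30000 nM in this assay, at which 1 of the 2 values shown sits. Compound 2 `CN(Cc1ccccc1)C(=O)c1ccc(-c2cc(C3=CC(=O)C=CC3=O)no2)s1` carries a different group on an aromatic carbon of the shared core, and in this assay compound 2 gives 11000 nM. For the measured compounds named here, that is the only measured step in the set: an at least 2.7-fold lower number from compound 1 to compound 2 (0.43 log units; beyond the scatter). Compound 3 `COc1ccc(OC)c(-c2cc(-c3ccc(C(=O)N4CCCC4)s3)on2)c1` has not yet been measured. It differs from compound 1 on the carbonyl carbon: pyrrolidin-1-yl in place of benzyl(methyl)amino on a carbonyl carbon. Going by the values given here, the measured step from compound 1 to compound 2 sits on an aromatic carbon and leaves the amide untouched, so no measured step bears on the change to compound 3. Compound 1 stands at a limit, so only a direction away from that limit could be weighed, and nothing measured at the amide position supports one. Without such support the expected step is written as a step that the limit leaves unreadable from compound 1 to compound 3. Compound 3 is therefore expected in this assay near 40000 nM, within a range from 12000 nM to 120000 nM, and most likely once more reported only as a limit.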

Compound 3, half-maximal inhibitory concentration: > 30000 nM
Compound 3: no number, only a limit; the forecaster's own chance of this, stated with the estimate: 70%; the middle value does not contradict the limit.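

In this assay compound 3 gives > 30000 nM which is a limit of the assay and not a number. Compound 1 stands at the same limit, so the step between compound 1 and compound 3 cannot be read. The compounds shown leave open what pyrrolidin-1-yl in place of benzyl(methyl)amino on a carbonyl carbon does in a compound that gives a number in this assay, such as compound 2.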